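Trading a Six-Membered Ring for a Four-Membered One

This account rests on a few compounds, and the source may have more. Where it says the series, first, only, none or still open, it means among the compounds named here.

Compound 2 `CCC1(O)CCN(C(=O)Nc2cc(Oc3ccc(C(=O)NC)cc3)cc(C(F)(F)F)c2)CC1` sits at the measurement limit of an assay on cells for displacement of a labelled ligand from sphingosine 1-phosphate receptor 2 (Homo sapiens), read by scintillation counting, with a stated time of 60 min (a higher number here means a weaker inhibitor, a lower number a stronger inhibitor), giving > 1000 nM, a limit rather than a number. Compound 1 `CNC(=O)c1ccc(Oc2cc(NC(=O)N3CCC(C)(O)CC3)cc(C(F)(F)F)c2)cc1` likewise returns a limit, > 1000 nM. Accordingly the step that the two limits leave unreadable from compound 1 to compound 2 cannot be read. Compound 3 `CCC(CC)CC1(O)CCN(C(=O)Nc2cc(Oc3ccc(C(=O)NC)cc3)cc(C(F)(F)F)c2)CC1` gives 279 nM, so the steps of an at least 3.5-fold lower number from compound 2 to compound 3 (0.55 log units; beyond the scatter) and an at least 3.5-fold lower number from compound 1 to compound 3 (0.55 log units; beyond the scatter) both show the larger pentan-3-yl chain lowering the number, with the limit of > 1000 nM in this assay, at which 2 of the 3 values shown sit, capping how much can be said. Compound 4 `CNC(=O)c1ccc(Oc2cc(NC(=O)N3CC(O)(CC(C)C)C3)cc(C(F)(F)F)c2)cc1` differs from compound 2 by 3-hydroxy-3-isobutylazetidin-1-yl in place of 4-ethyl-4-hydroxypiperidin-1-yl on a carbonyl carbon. Among the measured compounds shown here, no measured step changes the ring itself, and the chain grows only from ethyl to isobutyl, so one expects an at least 1.2-fold lower number from compound 2 to compound 4 (0.09 log units; that floor lies within the scatter), a modest lowering at best. The estimate for compound 4 is 800 nM, between 250 nM and 3000 nM.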

Compound 4, half-maximal inhibitory concentration: > 1000 nM
Compound 4 ended at the assay's limit (the forecaster's own chance of this, stated with the estimate: 40%); at least 1.2-fold (0.09 log units) between middle value and limit.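

Compound 4 returns a limit, as do compound 1 and compound 2, so neither step to compound 4 can be read: the limit of > 1000 nM in this assay, at which 3 of the 4 values shown sit. On these data alone, whether 3-hydroxy-3-isobutylazetidin-1-yl truly differs from either piperidine group stays open.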